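Swapping the ether group on a chloro-bearing ring

The source may hold more compounds than are shown below. What is called first, only, known or untested is meant among the compounds shown, and "the series" means these compounds.

Measured so far:
Compound 1, `CC(C)CCn1ccc(-c2ccc(OCC3CC3)cc2)c(C#N)c1=O`, gives 192%.
Compound 2, `CC(C)CCn1ccc(-c2ccc(OCC3CC3)c(Cl)c2)c(C#N)c1=O`, gives 206%.

Both numbers come from a functional assay on CHO cells for positive allosteric modulation of metabotropic glutamate receptor 2 (Homo sapiens), read by scintillation counting and GTPgammaS binding, with a stated time of 30 min; on this read-out higher numbers stand for larger maximal responses and lower numbers for smaller maximal responses. Compound 2 stands highest of the two measured numbers; its nearest neighbour is compound 1, and the step of a number 14 percentage points higher from compound 1 to compound 2 (beyond the scatter) lies beyond the usual scatter, so the chloro-for-hydrogen change on the aromatic carbon raised the maximal response modestly.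

Compound 3, `CC(C)CCn1ccc(-c2ccc(OC3CCOCC3)c(Cl)c2)c(C#N)c1=O`, has not been measured. It keeps the chlorine of compound 2 and differs only at the ether: oxan-4-yl in place of cyclopropylmethyl on an oxygen on an aromatic ring. Going by the values given here, no measured pair shows this kind of change, since the only measured step concerns the chloro substituent and not the group on the oxygen. There is therefore no direct guide, and the expectation rests on the assumption that the rest of the molecule, shared with compound 2, carries most of the response.

Compound 3 is thus expected to give 198%, within roughly 165% to 230%. This estimate means a step of a number 8 percentage points lower from compound 2 to compound 3 (within the scatter), which is expected to stay within the scatter rather than mark a real change.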

Compound 3, largest response reached (Emax), in percent of the reference or control that the assay uses: 197%
Estimate against measurement, compound 3: 1 percentage points above; measured number inside the range.
By their numbers in this assay, from the lowest: compounds 1, 3 and 2 (each within the scatter of the next, the first and the last beyond it).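

In this assay, oxan-4-yl in place of cyclopropylmethyl on an oxygen on an aromatic ring produces a number 9 percentage points lower from compound 2 to compound 3 (within the scatter), so this swap cannot be told apart from no change. Compound 2 showed only that cyclopropylmethyl at this oxygen goes with a high maximal response; compound 3 adds that a group of 6 heavy atoms, with a six-membered ring and 1 hydrogen-bond acceptor, can take the place of one with 4 heavy atoms, a three-membered ring and no acceptor, without a loss that stands out from the scatter. No measurement here explains why the maximal response holds across such different groups.

From the compounds shown here alone, it remains open whether the same holds for groups of other kinds on this oxygen, such as a plain methyl, a longer chain or a chain ending in an amine. Going by these compounds, it is also open how oxan-4-yl would read on the chlorine-free ring of compound 1, since compound 1 and compound 3 differ in two places and say nothing about this on their own.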